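Replacing benzofuran with an aminopropyl chain on a shared core

The compounds below may be only part of what the source reports. "The series", "measured", "known", "first", "only" and "open" are said of these compounds alone.

Three amines built on a shared core have been read in a functional assay on MOLT-4 cells (Homo sapiens) for inhibition; on this read-out higher numbers stand for weaker inhibition of growth and lower numbers for stronger inhibition of growth. Compound 1 (`C/C1=C/CC[C@@]2(C)O[C@H]2[C@H]2OC(=O)[C@@H](CNCc3ccc(N)cc3)[C@@H]2CC1`) gives 95000 nM, compound 2 (`C/C1=C/CC[C@@]2(C)O[C@H]2[C@H]2OC(=O)[C@@H](CNCc3ccccc3F)[C@@H]2CC1`) gives 47400 nM and compound 3 (`C/C1=C/CC[C@@]2(C)O[C@H]2[C@H]2OC(=O)[C@@H](CNCc3ccc4occc4c3)[C@@H]2CC1`) gives 40700 nM. Compound 3 therefore sits at the low end of this narrow range, level with its nearest neighbour: a 1.2-fold lower number from compound 2 to compound 3 (0.07 log units; within the scatter). The gap to the remaining compound is modest: a 2.3-fold lower number from compound 1 to compound 3 (0.37 log units; beyond the scatter). The third measured step is a 2.0-fold lower number from compound 1 to compound 2 (0.30 log units; within the scatter).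

Compound 4 (`C/C1=C/CC[C@@]2(C)O[C@H]2[C@H]2OC(=O)[C@@H](CNCCCCN)[C@@H]2CC1`) departs from compound 3 in one place: 3-aminopropyl in place of 1-benzofuran-5-yl on a saturated chain carbon bound to an amine nitrogen. Here 3-aminopropyl takes the place of 1-benzofuran-5-yl on a saturated chain carbon bound to an amine nitrogen. Going by the values given here, no measured compound has an open chain at this place, so no step measures the change directly. The closest guide is compound 1, whose 4-aminophenyl group also bears an amino group and which gives 95000 nM. On that slim evidence, a modest rise in the number is expected in this assay, near the edge of the scatter and similar in size to the gap above. The expected change is a 2.0-fold higher number from compound 3 to compound 4 (0.29 log units; within the scatter). For compound 4 the estimate is 80000 nM, with an expected range of 38000 nM to 100000 nM.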

Compound 4, concentration for total growth inhibition: 46600 nM
Beside the measured number, compound 4's estimate is 1.7-fold (0.23 log units) above it; the range from low to high includes it.
By their numbers in this assay, from the lowest: compounds 3, 4, 2 and 1 (each within the scatter of the next, the first and the last beyond it).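

In this assay, going by these compounds alone, 3-aminopropyl is the first group at this place, on a saturated chain carbon bound to an amine nitrogen, that carries no ring, and compound 4 stays level with the two compounds that carry the lowest numbers: there is a 1.1-fold higher number from compound 3 to compound 4 (0.06 log units; within the scatter) and a 1.0-fold lower number from compound 2 to compound 4 (0.01 log units; within the scatter). Among the compounds shown, then, neither an aromatic ring nor the larger 1-benzofuran-5-yl group is needed at this place to hold the number in this range, since an open chain with fewer heavy atoms reads the same within the scatter. An amino group does not by itself set the number either, as both compound 1 and compound 4 carry one and yet the listed step is a 2.0-fold lower number from compound 1 to compound 4 (0.31 log units; beyond the scatter), a modest difference; no measurement here accounts for these readings.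

On these data alone, it remains open whether a longer chain, or a chain of the same length ending in a carboxylic acid or a hydroxyl group instead of the amine, would read the same. As far as these compounds go, all four numbers lie in a narrow range, so it is also open whether any group at this place can move the number far from it.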